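The source may report more compounds than this note shows. Statements on the series, on what has been measured and on what is new or still open speak of the compounds shown alone.

Of the compounds shown here, two have so far been measured in a functional assay on HEK293 cells with D(4) dopamine receptor (Homo sapiens) as the target, read by FLIPR; on this read-out lower numbers stand for an effect already at smaller amounts and higher numbers for an effect only at larger amounts of compound. Compound 1 `O/N=C(\CCN1CCN(c2ccccn2)CC1)c1ccc(F)cc1F` gives 8.9 nM in this assay, whereas compound 2 `CCO/N=C(\CCN1CCN(c2ccccc2C#N)CC1)c1ccccc1` gives 48.7 nM. Of these two numbers, compound 2 carries the higher one, and its gap to compound 1 lies beyond the usual scatter of repeated measurements. Compound 3 `CCO/N=C(\CCN1CCN(c2ncccn2)CC1)c1ccccc1` has not been measured yet; it departs from compound 2 in one place: pyrimidin-2-yl in place of 2-cyanophenyl on an amine nitrogen in a ring. For the measured compounds named here, no measured pair shows this particular change, so its effect can only be judged from the two numbers at hand and the nature of the replacement. The expectation is a modest step, if any, toward lower numbers, with the step expected a 1.6-fold lower number from compound 2 to compound 3 (0.21 log units; within the scatter) staying close to or within the scatter. Compound 3 is therefore estimated to give 30 nM in this assay, within a range from 8 nM to 120 nM.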

Compound 3, half-maximal effective concentration: 615 nM
Compound 3: the middle estimate sits 21-fold (1.31 log units) below what was measured, outside the stated range (above it).
By their numbers in this assay, from the lowest: compound 1; then compound 2; then compound 3.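

In this assay, pyrimidin-2-yl in place of 2-cyanophenyl on the amine nitrogen in the ring gives a 13-fold higher number from compound 2 to compound 3 (1.10 log units; beyond the scatter), a large step beyond the scatter. This position, three ring bonds from the ring nitrogen, is therefore far from indifferent to the aromatic ring it carries, which the two earlier compounds could not show, since they differ from each other in more than one place. Nothing at hand bears on why the number rises with this change.

As far as these compounds go, it remains open whether the step follows the nitrile, the ring of carbon only, or the two ring nitrogens of the pyrimidine. An unsubstituted phenyl or a 2-methoxyphenyl on the same nitrogen, with the rest of compound 2 kept, would begin to separate these.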